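Swapping 1-methylcyclopropyl for tert-butyl on compound 3

This account rests on a few compounds, and the source may have more. Where it says the series, first, only, none or still open, it means among the compounds named here.

Measured in a functional assay on a cell-free system (plasma, Homo sapiens), with a stated time of 3 min; a lower number here means a stronger inhibitor, a higher number a weaker inhibitor:
- compound 1 `Cc1cccc([C@@H](O)C(=O)N2N=CC[C@H]2C(=O)NCc2cc(Cl)ccc2-n2cnnn2)c1` gives 830 nM
- compound 2 `O=C(NCc1cc(Cl)ccc1-n1cnnn1)[C@@H]1CC=NN1C(=O)[C@H](O)c1ccccc1` gives 840 nM
- compound 3 `CC1(C[C@@H](O)C(=O)N2N=CC[C@H]2C(=O)NCc2cc(Cl)ccc2-n2cnnn2)CC1` gives 730 nM

The value of compound 3 cannot be told apart from the other two, as a 1.1-fold lower number from compound 1 to compound 3 (0.06 log units; within the scatter) and a 1.2-fold lower number from compound 2 to compound 3 (0.06 log units; within the scatter) show. Both steps replaced the whole group that carries the piece changing here, and neither moved the number beyond the scatter. Compound 4 `CC(C)(C)C[C@@H](O)C(=O)N1N=CC[C@H]1C(=O)NCc1cc(Cl)ccc1-n1cnnn1` has tert-butyl in place of 1-methylcyclopropyl on a saturated chain carbon, two bonds along the chain from a carbonyl carbon and an oxygen on a saturated carbon. For the measured compounds named here, no measured pair tests this exact swap. In this assay, no shift beyond the scatter is therefore expected, and the expected step is a 1.0-fold higher number from compound 3 to compound 4 (0.02 log units; within the scatter). The estimated value for compound 4 is 760 nM, with an expected range of 420 nM to 1400 nM.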

Compound 4, half-maximal inhibitory concentration: 590 nM
For compound 4 the middle estimate is 1.3-fold (0.11 log units) above the measured one; the measured number falls inside the stated range.
By their numbers in this assay, from the lowest: compounds 4, 3, 1 and 2 (each within the scatter of the next).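

Tert-butyl, which has no ring, stands in for 1-methylcyclopropyl with the same count of 4 heavy atoms, and the reading in this assay stays within the scatter (a 1.2-fold lower number from compound 3 to compound 4 (0.09 log units; within the scatter)). Neopentyl in place of phenyl (a 1.4-fold lower number from compound 2 to compound 4 (0.15 log units; within the scatter)) or of 3-methylphenyl (a 1.4-fold lower number from compound 1 to compound 4 (0.15 log units; within the scatter)) also stays within it, so all four compounds read alike at this place. Nothing measured here offers a reason for this. Going by these compounds, whether an amine or a carboxylic acid at this place would move the number beyond the scatter stays open.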